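A few compounds are considered here, and "the series" means these few. Any claim that something is new, unique, unknown or untested is made for them only; others in the source may bear on it.

Of the compounds shown here, three built on one shared core have been measured in an assay for inhibition of 6-phosphofructo-2-kinase/fructose-2,6-bisphosphatase 3 (Homo sapiens), read by ADP-Glo, with a stated time of 2 h; a higher number here means a weaker inhibitor, a lower number a stronger inhibitor. Compound 1 `CC(=O)N1CCC(NC(=O)c2ccncc2Nc2cc(-c3ccc4ccn(C)c4c3)c3nccnc3c2)CC1` gives 18 nM. Compound 2 `CC(=O)N1CCCC(NC(=O)c2ccncc2Nc2cc(-c3ccc4ccn(C)c4c3)c3nccnc3c2)C1` gives 11 nM. Compound 3 `CN1CC(NC(=O)c2ccncc2Nc2cc(-c3ccc4ccn(C)c4c3)c3nccnc3c2)CCC1=O` gives 116 nM, the highest of the three numbers, and it stands apart from both others by more than the usual scatter, so it is the weakest inhibitor among them. The step of a 1.6-fold lower number from compound 1 to compound 2 (0.21 log units; within the scatter) stays within the scatter. The steps of a 6.4-fold higher number from compound 1 to compound 3 (0.81 log units; beyond the scatter) and an 11-fold higher number from compound 2 to compound 3 (1.02 log units; beyond the scatter) show that replacing an acetylated ring nitrogen by a methyl-bearing ring nitrogen with a ring carbonyl raises the number clearly.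

Compound 4 `CC(=O)N1CC(CNC(=O)c2ccncc2Nc2cc(-c3ccc4ccn(C)c4c3)c3nccnc3c2)C1` has not yet been measured. It differs from compound 3 in one place: (1-acetylazetidin-3-yl)methyl in place of 1-methyl-6-oxopiperidin-3-yl on an amide-type nitrogen. The incoming group once more carries an acetyl group on a ring nitrogen, as compounds 1 and 2 do, though on a different ring and attached through a methyl. The two steps that lead from compound 1 and compound 2 to compound 3 are the ones that bear on this change, and running that kind of swap backwards suggests a lower number. A step of a 3.3-fold lower number from compound 3 to compound 4 (0.52 log units; beyond the scatter) is therefore expected in this assay. Compound 4 is estimated at 35 nM, with a likely range from 12 nM to 110 nM.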

Compound 4, half-maximal inhibitory concentration: 137 nM
Compound 4: middle estimate off by 3.9-fold (0.59 log units), on the low side; the whole stated range lies below it.
By their numbers in this assay, from the lowest: compounds 2 and 1 (each within the scatter of the next); then compounds 3 and 4 (each within the scatter of the next).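

In this assay this change gives a 1.2-fold higher number from compound 3 to compound 4 (0.07 log units; within the scatter) and so lies within the scatter: on this amide-type nitrogen, (1-acetylazetidin-3-yl)methyl and 1-methyl-6-oxopiperidin-3-yl cannot be told apart, even though one has a four-membered ring and the other a six-membered ring. An acetyl group on a ring nitrogen is therefore not enough to bring the number down, since compound 4 carries one and goes against the link seen in compound 1 and compound 2, with the swaps giving a 12-fold higher number from compound 2 to compound 4 (1.10 log units; beyond the scatter) and a 7.6-fold higher number from compound 1 to compound 4 (0.88 log units; beyond the scatter) both beyond the scatter. No measurement shown here accounts for this result.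

Compound 4 differs from the acetylpiperidine compounds in both its ring and its methyl link, so the compounds shown cannot say which of the two carries the loss. As far as these compounds go, a 1-acetylazetidin-3-yl group placed directly on the amide nitrogen and a (1-acetylpiperidin-4-yl)methyl group would each change only one of these features, and a 1-acetylpyrrolidin-3-yl group, with its five-membered ring, also remains open.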